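This account rests on a few compounds, and the source may have more. Where it says the series, first, only, none or still open, it means among the compounds named here.

Measured so far in an ADME assay on Vero cells (Chlorocebus sabaeus) for cytotoxicity, read by MTT assay, with a stated time of 72 h; on this read-out higher numbers stand for lower toxicity in this test and lower numbers for higher toxicity in this test:

Compound 1, `COC(=O)c1cc(-c2cccc(NC(=O)c3ccc(/C=C/C(=O)c4ccccc4)cc3)c2)on1`: > 50 ug/mL
Compound 2, `CCOc1ccc(C(=O)/C=C/c2ccc(C(=O)Nc3cccc(-c4cc(C(=O)OC)no4)c3)cc2)cc1`: > 40 ug/mL
Compound 3, `COC(=O)c1cc(-c2cccc(NC(=O)c3ccc(/C=C/C(=O)c4ccc(Cl)cc4Cl)cc3)c2)on1`: > 40 ug/mL

Each of these values is a limit of this assay, not a measured number. For compound 1 the reading > 50 ug/mL is such a limit; the two further values shown are limits too, so compound 1 cannot be placed above or below the others. The unmeasured compound 4, `COC(=O)c1cc(-c2cccc(NC(=O)c3ccc(/C=C/C(=O)c4ccccc4OC)cc3)c2)on1`, differs from compound 1 by methoxy in place of hydrogen on an aromatic carbon. The closest measured step is a step that the two limits leave unreadable from compound 1 to compound 2, and the related steps a step that the two limits leave unreadable from compound 1 to compound 3 and a step that the two limits leave unreadable from compound 2 to compound 3 are equally unreadable, because all three compounds sit at the limit of > 40 ug/mL in this assay, at which 2 of the 3 values shown sit, or (the limit of > 50 ug/mL in this assay, at which 1 of the 3 values shown sits). For the measured compounds named here, no step of readable size is therefore known for this kind of change, and nothing suggests a move beyond the scatter in this assay. Compound 4 is expected to give 50 ug/mL, with a likely range from 25 ug/mL to 100 ug/mL. The step of a number no higher from compound 1 to compound 4 (the limit leaves the size open) that this estimate means is expected to lie within the scatter.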

Compound 4, half-maximal cytotoxic concentration: > 40 ug/mL
Compound 4: only a limit was reported (the forecaster's own chance of this, stated with the estimate: 80%); the middle value is on the limit's open side.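

In this assay compound 4 gives > 40 ug/mL, a limit and not a number. No step between compound 4 and compound 1, compound 2 or compound 3 can be read, because the values are all limits: the limit of > 40 ug/mL in this assay, at which 3 of the 4 values shown sit.

The compounds shown leave open what concentration of any of them is actually toxic to these cells, and whether methoxy in place of hydrogen changes it.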